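Chloro in Place of Trifluoromethyl on the Diaryl Urea

The source may hold more compounds than are shown below. What is called first, only, known or untested is meant among the compounds shown, and "the series" means these compounds.

Compound 1 `COc1cc2cc(Oc3ccc(NC(=O)Nc4cccc(C(F)(F)F)c4)cc3)c(C)nc2cc1OC`: 7410 nM
Compound 2 `COc1cc2cc(Oc3ccc(NC(=O)Nc4ccc(Cl)c(C(F)(F)F)c4)cc3)c(C)nc2cc1OC`: 3790 nM

In a functional assay on NCI-H23 cells (Homo sapiens) for inhibition, read by sulforhodamine B assay, with a stated time of 48 h (a higher number here means a weaker inhibitor of growth, a lower number a stronger inhibitor of growth), compound 1 gives 7410 nM, and compound 2 gives 3790 nM. Going by the values given here, the one measured step between them, a 2.0-fold lower number from compound 1 to compound 2 (0.29 log units; within the scatter), adds a chloro in place of a hydrogen on an aromatic carbon and stays within the scatter. Among the compounds with values here, compound 2 thus has the lower of the two numbers, but its only neighbour, compound 1, lies within the scatter of it, so no order can be read from these two values.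

Compound 3 `COc1cc2cc(Oc3ccc(NC(=O)Nc4ccc(Cl)c(Cl)c4)cc3)c(C)nc2cc1OC` has not yet been measured. Its difference from compound 2 is chloro in place of trifluoromethyl on an aromatic carbon. Within the data shown here, no measured step swaps a trifluoromethyl for a chloro; the only step known, from compound 1 to compound 2, concerns a different position and was within the scatter. On this basis compound 3 is expected to give a number close to that of compound 2, with no step beyond the scatter. For compound 3 the estimate is 4500 nM, within 1500 nM to 13000 nM, which means an expected step of a 1.2-fold higher number from compound 2 to compound 3 (0.07 log units; within the scatter).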

Compound 3, concentration for total growth inhibition: 15900 nM
Estimate against measurement, compound 3: 3.5-fold (0.55 log units) below, outside the stated range (above it).
By their numbers in this assay, from the lowest: compounds 2 and 1 (each within the scatter of the next); then compound 3.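

In this assay, going by these compounds alone, the exchange at this aromatic carbon gives a 4.2-fold higher number from compound 2 to compound 3 (0.62 log units; beyond the scatter) and so provides the first step that lies beyond the scatter: trifluoromethyl and chloro are not interchangeable here, even though the chloro already on the ring stays the same. The 3,4-dichlorophenyl compound also separates from the compound without that second substituent, with a 2.1-fold higher number from compound 1 to compound 3 (0.33 log units; beyond the scatter) on the change to 3,4-dichlorophenyl from 3-(trifluoromethyl)phenyl, which makes compound 3 the weakest inhibitor of growth of the three, since its steps to both others are beyond the scatter. Nothing measured alongside these values accounts for the difference between the two groups.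

From the compounds shown here alone, whether a methyl, a methoxy or a nitrile on that same aromatic carbon would fall nearer to compound 2 or nearer to compound 3 remains open. Also open, going by these compounds, is whether the exchange of trifluoromethyl for chloro would give a step of similar size if the neighbouring chloro were replaced by a fluoro or a methyl.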